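Compound 3 and the step to (4-bromobenzyl)amino

This account rests on a few compounds, and the source may have more. Where it says the series, first, only, none or still open, it means among the compounds named here.

In an ADME assay on A549 cells (Homo sapiens) for cytotoxicity, read by resazurin assay, with a stated time of 48 h (a higher number here means that more compound is tolerated, a lower number that less compound is tolerated), compound 3 `CCN(CC)c1ccc(NC(=O)c2cc(Cl)ccc2O)c(Cl)c1` gives 55500 nM. Compound 1 `CCNc1ccc(NC(=O)c2cc(Cl)ccc2O)c(Cl)c1` gives 30200 nM, and compound 2 `CN(C)c1ccc(NC(=O)c2cc(Cl)ccc2O)c(Cl)c1` gives 85100 nM. Compound 3 lies within the scatter of both others, at a 1.8-fold higher number from compound 1 to compound 3 (0.26 log units; within the scatter) and a 1.5-fold lower number from compound 2 to compound 3 (0.19 log units; within the scatter). Only the remaining pair differs by more than the scatter, at a 2.8-fold higher number from compound 1 to compound 2 (0.45 log units; beyond the scatter), a modest step.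

Compound 4 `O=C(Nc1ccc(NCc2ccc(Br)cc2)cc1Cl)c1cc(Cl)ccc1O` differs from compound 3 by a larger exchange: (4-bromobenzyl)amino in place of diethylamino on an aromatic carbon. All three measured steps swap small amino groups at this same place, and none brings in a ring, so they are only a loose guide to so large a change. Compound 4 does share a hydrogen on that nitrogen with compound 1, whose value is 30200 nM. On that single parallel, a modest fall in this assay is expected rather than no change, and the estimated step is a 3.1-fold lower number from compound 3 to compound 4 (0.49 log units; beyond the scatter). For compound 4 the estimated value is 18000 nM, with an expected range from 5000 nM to 55000 nM.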

Compound 4, half-maximal cytotoxic concentration: 40900 nM
Beside the measured number, compound 4's estimate is 2.3-fold (0.36 log units) below it; low and high end bracket the measured number.
By their numbers in this assay, from the lowest: compounds 1, 4, 3 and 2 (each within the scatter of the next, the first and the last beyond it).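

In this assay, within the data shown here, a position that had so far carried only small amino groups also accepts (4-bromobenzyl)amino, with its six-membered aromatic ring and bromine, without a change beyond the scatter against two of the earlier compounds (a 1.4-fold lower number from compound 3 to compound 4 (0.13 log units; within the scatter); a 1.4-fold higher number from compound 1 to compound 4 (0.13 log units; within the scatter)). Only the comparison with the dimethylamino compound goes beyond the scatter, and that step is modest (a 2.1-fold lower number from compound 2 to compound 4 (0.32 log units; beyond the scatter)). Across the compounds shown, then, adding a ring at this aromatic carbon gives no step larger than the one already seen between the two small amino groups of compound 1 and compound 2. No evidence is available to explain these numbers. As far as these compounds go, it remains open whether the bromine matters here, which a plain benzylamino group or a 4-methoxybenzylamino group would test, and whether a saturated ring such as morpholine would fit the same range.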